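A few compounds are considered here, and "the series" means these few. Any claim that something is new, unique, unknown or untested is made for them only; others in the source may bear on it.

In a functional assay on A549 cells (Homo sapiens) for antiproliferative activity, read by MTT assay, with a stated time of 72 h (a lower number here means a stronger inhibitor, a higher number a weaker inhibitor), compound 1 `O=C(N/N=C/c1cccc(Br)c1)Nc1ccc(Oc2ccnc3[nH]ccc23)c(F)c1` gives 2220 nM while compound 2 `O=C(N/N=C/c1ccc(Br)cc1)Nc1ccc(Oc2ccnc3[nH]ccc23)c(F)c1` gives 820 nM and compound 3 `O=C(N/N=C/c1ccc(Br)cc1)Nc1ccc(Oc2ccnc3[nH]ccc23)cc1` gives 640 nM in the same test. The step of a 1.3-fold lower number from compound 2 to compound 3 (0.11 log units; within the scatter) for hydrogen in place of fluoro on an aromatic carbon leaves these two level, and both sit under compound 1. For the measured compounds named here, compound 4 `CN(C)CCn1cccc1/C=N/NC(=O)Nc1ccc(Oc2ccnc3[nH]ccc23)cc1` carries 1-(2-(dimethylamino)ethyl)-1H-pyrrol-2-yl in place of 4-bromophenyl on a carbon with a double bond to nitrogen as its only change. Going by the values given here, the one measured change at that end, a 2.7-fold lower number from compound 1 to compound 2 (0.43 log units; beyond the scatter) for 4-bromophenyl in place of 3-bromophenyl, is modest and replaces no ring, so it sets no direction. The expected step is a 1.3-fold higher number from compound 3 to compound 4 (0.10 log units; within the scatter) with a wide margin either way. Compound 4 is estimated at 800 nM within a range of 170 nM to 3800 nM in this assay for now.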

Compound 4, half-maximal inhibitory concentration: "not active" (no number reported)
No number was reported for compound 4, and the estimate cannot be compared.
By their numbers in this assay, from the lowest: compounds 3 and 2 (each within the scatter of the next); then compound 1.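

For the compounds shown here, compound 4 is reported as not active in this assay, with no number, so no step from compound 3 can be read. What the compounds shown leave open is how the 1-(2-(dimethylamino)ethyl)-1H-pyrrol-2-yl group relates to this result, and no available evidence bears on it.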